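The source may report more compounds than this note shows. Statements on the series, on what has been measured and on what is new or still open speak of the compounds shown alone.

Working notes on the series. Compound 1 `CCCCC(C)(C)[C@H](O)/C=C/[C@H]1CCC(=O)N1CCSc1nc(C(=O)O)cs1` in an assay on isolated protein for agonist activity at prostaglandin E2 receptor EP3 subtype (Homo sapiens) (a lower number here means that less compound is needed, a higher number that more compound is needed for the effect), gives 8.4 nM. For the measured compounds named here, compound 2 `CCOCCC1([C@H](O)/C=C/[C@H]2COC(=O)N2CCSc2nc(C(=O)O)cs2)CCC1` in this assay gives 2610 nM; this is the highest of the two numbers so far, with compound 1 standing a long way lower, beyond the scatter. Going by the values given here, compound 1 and compound 2 differ in several places at once, so no single step between measured compounds is available.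

Compound 3 `O=C(O)c1csc(SCCN2C(=O)OC[C@@H]2/C=C/[C@@H](O)C2(CCc3ccccc3)CCC2)n1` is the next member and differs from compound 2 in one place: phenyl in place of ethoxy on a saturated chain carbon, two bonds along the chain from a saturated ring carbon. Among the compounds with values here, no measured pair shows this particular change, so the expectation rests on the two values above only. The step from compound 2 to compound 3 is expected to be a 2.6-fold lower number from compound 2 to compound 3 (0.42 log units; beyond the scatter), toward a lower number, though a change beyond the scatter in either direction cannot be excluded. Compound 3 in this assay is estimated at 1000 nM, within a range from 150 nM to 7000 nM.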

Compound 3, half-maximal effective concentration: 27 nM
For compound 3 the middle estimate is 37-fold (1.57 log units) above the measured one, outside the stated range (below it).
By their numbers in this assay, from the lowest: compound 1; then compound 3; then compound 2.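

At this position, on a saturated chain carbon, two bonds along the chain from a saturated ring carbon, the choice of end group matters strongly in this assay: phenyl in place of ethoxy gives a 97-fold lower number from compound 2 to compound 3 (1.99 log units; beyond the scatter), a large step. Read one bond further out, this is 2-ethoxyethyl to phenethyl, so the step combines the arrival of an aromatic ring of carbon only with the loss of the ethoxy oxygen, and this single pair cannot separate the two. Nothing measured among the data shown explains the size of this step.

As far as these compounds go, it remains open whether the aromatic ring is required, or whether a cyclohexyl group or a plain butyl chain at the same place would give a comparable step. Also open, from the compounds shown here alone, is whether the step carries over to the core of compound 1, and how a methoxy group or a fluorine on the phenyl ring would read.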